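From 2,4-Dimethoxyphenyl to 4-Hydroxyphenyl in a Cell Assay

The source may report more compounds than this note shows. Statements on the series, on what has been measured and on what is new or still open speak of the compounds shown alone.

Of the compounds shown here, three sharing one core have been read in a functional assay on HCT-116 cells (Homo sapiens) for inhibition, read by MTT assay, with a stated time of 48 h; a lower number here means a stronger inhibitor, a higher number a weaker inhibitor. Compound 1 `COc1cc(-c2cc(-c3ccc(Cl)cc3)nc(-c3ccccc3)n2)cc(OC)c1OC`, bearing 4-chlorophenyl, gives 7980 nM. Compound 2 `COc1cc(-c2cc(-c3cccc([N+](=O)[O-])c3)nc(-c3ccccc3)n2)cc(OC)c1OC`, bearing 3-nitrophenyl, has a limit rather than a number, > 25000 nM. Compound 3 `COc1ccc(-c2cc(-c3cc(OC)c(OC)c(OC)c3)nc(-c3ccccc3)n2)c(OC)c1`, bearing 2,4-dimethoxyphenyl, likewise has only a limit, > 25000 nM.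

Compound 4 `COc1cc(-c2cc(-c3ccc(O)cc3)nc(-c3ccccc3)n2)cc(OC)c1OC` keeps the shared core but carries 4-hydroxyphenyl in place of 2,4-dimethoxyphenyl on an aromatic carbon. Two measured steps at this same place bear on the change. Swapping out 4-chlorophenyl gave an at least 3.1-fold higher number from compound 1 to compound 2 (0.49 log units; beyond the scatter) with 3-nitrophenyl and an at least 3.1-fold higher number from compound 1 to compound 3 (0.49 log units; beyond the scatter) with 2,4-dimethoxyphenyl, so the group here can move the number beyond the scatter. The remaining step, a step that the two limits leave unreadable from compound 2 to compound 3, says nothing about size.

The entering 4-hydroxyphenyl is closer in name to the 4-chlorophenyl of compound 1, at 7980 nM, than to the groups on compound 2 and compound 3. This resemblance is weak support, and a reading at the limit of this assay remains quite possible. The expected change is a modest one toward a lower number, stated as an at least 2.0-fold lower number from compound 3 to compound 4 (0.31 log units; beyond the scatter). Compound 4 is estimated at 12000 nM, with an expected range from 4000 nM to 25000 nM.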

Compound 4, half-maximal inhibitory concentration: 11900 nM
For compound 4 the middle estimate is 1.0-fold (0.00 log units) above the measured one; the range from low to high includes it.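

In this assay, this position now has a second group that gives a readable number rather than a limit. Placing 4-hydroxyphenyl here gives an at least 2.1-fold lower number from compound 3 to compound 4 (0.32 log units; beyond the scatter) and an at least 2.1-fold lower number from compound 2 to compound 4 (0.32 log units; beyond the scatter), so leaving the limit does not depend on 4-chlorophenyl alone. Hydroxy in place of chloro gives a 1.5-fold higher number from compound 1 to compound 4 (0.17 log units; within the scatter), so the assay does not tell these two compounds apart. The two groups that give a number share the 4 in their names, but compound 3, with its 2,4-dimethoxyphenyl, goes against reading that as a rule. The full size of the two steps stays unknown because they start from a limit: the limit of > 25000 nM in this assay, at which 2 of the 4 values shown sit.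

The compounds shown leave open whether 4-methoxyphenyl at this place would read like compound 4 or like compound 3, which would show whether the second methoxy group of compound 3 matters. They also leave open whether an amine or a carboxylic acid in the place of the hydroxy group of compound 4 would keep a readable number or return to the limit.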